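The source may report more compounds than this note shows. Statements on the series, on what has been measured and on what is new or still open speak of the compounds shown alone.

Measured compounds:
- Compound 1 `CN(C)CCn1cnnc1-c1cc(Oc2ccc(NC(=O)N/N=C/c3ccc(Cl)cc3Cl)cc2F)ccn1`, which in a functional assay on NCI-H460 cells (Homo sapiens) for cytotoxicity, read by MTT assay, with a stated time of 72 h (a lower number here means a stronger inhibitor, a higher number a weaker inhibitor), gives 130 nM
- Compound 2 `CN(C)CCn1cnnc1-c1cc(Oc2ccc(NC(=O)N/N=C/c3cc(C(C)(C)C)cc(C(C)(C)C)c3O)cc2F)ccn1`, which in this assay gives 590 nM
- Compound 3 `COc1ccc(OC)c(/C=N/NC(=O)Nc2ccc(Oc3ccnc(-c4nncn4CCN(C)C)c3)c(F)c2)c1`, which in this assay gives 2930 nM

Compound 3 carries the highest number of the measured set; its nearest neighbour is compound 2, and compound 1 lies furthest from it, so compound 3 is the weakest of the measured compounds in this assay. Compound 4 `CN(C)CCn1cnnc1-c1cc(Oc2ccc(NC(=O)N/N=C/c3ccccc3O[N+](=O)[O-])cc2F)ccn1` differs from compound 3 only at the group on the carbon with a double bond to nitrogen: 2-(nitrooxy)phenyl in place of 2,5-dimethoxyphenyl on a carbon with a double bond to nitrogen.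

For the measured compounds named here, only one measured step concerns this same position, and it was large: a 23-fold higher number from compound 1 to compound 3 (1.35 log units; beyond the scatter). That step shows that exchanging the aryl group here can move the number strongly, and the values of compound 2 and compound 3 point the same way. Nothing measured involves a nitrooxy group, so the direction for compound 4 cannot be read from a close precedent; since compound 3 sits at the top of the measured range, a move toward the lower numbers is the more likely outcome. Compound 4 is therefore expected to give about 900 nM, within a range from 250 nM to 3500 nM. This expectation amounts to an estimated step of a 3.3-fold lower number from compound 3 to compound 4 (0.51 log units; beyond the scatter).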

Compound 4, half-maximal inhibitory concentration: 1270 nM
Compound 4: middle estimate off by 1.4-fold (0.15 log units), on the low side; low and high end bracket the measured number.
By their numbers in this assay, from the lowest: compound 1; then compound 2; then compound 4; then compound 3.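

In this assay, the step of a 2.3-fold lower number from compound 3 to compound 4 (0.36 log units; beyond the scatter) shows that this position also responds to a nitrooxy-bearing aryl group, and that 2-(nitrooxy)phenyl on the carbon with a double bond to nitrogen gives a lower number than 2,5-dimethoxyphenyl, though this change is smaller than the one seen earlier at this position. The step of a 9.8-fold higher number from compound 1 to compound 4 (0.99 log units; beyond the scatter) shows that 2-(nitrooxy)phenyl still gives a clearly higher number than 2,4-dichlorophenyl, which keeps compound 1 the lowest of the three compared here. No measured property is available to explain these differences.

The compounds shown leave open whether the nitrooxy group itself matters, which a comparison with plain phenyl or 2-hydroxyphenyl would test. From the compounds shown here alone, how an amine or a carboxylic acid on this aryl ring would compare also remains unknown.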